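Adding a Second Hydroxy to the Chain: Expected Cytotoxicity

The source may hold more compounds than are shown below. What is called first, only, known or untested is meant among the compounds shown, and "the series" means these compounds.

Measured compounds:
compound 1, `CC(C)N(c1ccnc(Nc2ccc(C#N)cc2)n1)c1c(F)cc(-c2ccc(C#N)cc2)cc1F`, 172000 nM
compound 2, `N#Cc1ccc(Nc2nccc(N(CCCO)c3c(F)cc(-c4ccc(C#N)cc4)cc3F)n2)cc1`, 68000 nM

Two compounds share a core and differ only in the group on the ring nitrogen. In an ADME assay on MT4 cells (Homo sapiens) for cytotoxicity, read by MTT assay, with a stated time of 5 days (on this read-out lower numbers stand for higher toxicity in this test and higher numbers for lower toxicity in this test), compound 1 gives 172000 nM, and compound 2 gives 68000 nM, the lowest of the two numbers. Among the measured compounds shown here, the one step that has been measured, a 2.5-fold lower number from compound 1 to compound 2 (0.40 log units; beyond the scatter), came with 3-hydroxypropyl in place of isopropyl.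

Compound 3, `N#Cc1ccc(Nc2nccc(N(CC(O)CO)c3c(F)cc(-c4ccc(C#N)cc4)cc3F)n2)cc1`, is not yet measured. It differs from compound 2 by hydroxy in place of hydrogen on a saturated chain carbon bound to two saturated chain carbons. For the measured compounds named here, the only measured step that bears on this change is the one from compound 1 to compound 2, where the chain that carried a hydroxy group lowered the number in this assay by a modest amount. A second hydroxy on that same chain is a smaller change than the exchange of the whole group, so the expected step is small, if any, and in the same downward direction. Compound 3 is therefore expected at 55000 nM, within a range of 25000 nM to 120000 nM, which means an expected step of a 1.2-fold lower number from compound 2 to compound 3 (0.09 log units; within the scatter).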

Compound 3, half-maximal cytotoxic concentration: 19500 nM
For compound 3 the middle estimate is 2.8-fold (0.45 log units) above the measured one, outside the stated range (below it).
By their numbers in this assay, from the lowest: compound 3; then compound 2; then compound 1.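

The position on the chain is not a silent one. In this assay, hydroxy in place of hydrogen on a saturated chain carbon bound to two saturated chain carbons gives a 3.5-fold lower number from compound 2 to compound 3 (0.54 log units; beyond the scatter), so the change from 3-hydroxypropyl to 2,3-dihydroxypropyl moves the number in the same direction as the earlier exchange and does so beyond the usual scatter. Taken from the isopropyl compound, 2,3-dihydroxypropyl in place of isopropyl on the ring nitrogen gives an 8.8-fold lower number from compound 1 to compound 3 (0.95 log units; beyond the scatter), which leaves compound 3 as the one with the highest toxicity in this test among the three, and none of the three goes against the downward trend along this series of chains. Nothing available explains why the number falls at this carbon.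

Whether the fall belongs to hydroxy itself remains open, since the compounds shown do not tell how a methoxy, an amine or a carboxylic acid on the same carbon would read in this assay. From the compounds shown here alone, it is equally open whether the trend would continue on a longer chain carrying hydroxy, or whether it is confined to the chains seen here on this shared core.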